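Compound 3 to compound 4: a stereocentre left undrawn

This account rests on a few compounds, and the source may have more. Where it says the series, first, only, none or still open, it means among the compounds named here.

Measured so far in an ADME assay on MT4 cells (Homo sapiens) for cytotoxicity, read by MTT assay, with a stated time of 5 days; a higher number here means that more compound is tolerated, a lower number that less compound is tolerated:
Compound 1 `N#Cc1ccc(Nc2nccc(C(O)c3ccc(-c4ccc(C#N)cc4)cc3Cl)n2)cc1` gives 7540 nM
Compound 2 `N#Cc1ccc(Nc2nccc(C(O)c3ccc(-c4ccc(C#N)cc4)cc3F)n2)cc1` gives 14300 nM
Compound 3 `Cc1cc(-c2ccc(C#N)cc2)ccc1[C@H](O)c1ccnc(Nc2ccc(C#N)cc2)n1` gives 4000 nM

Compound 3, at 4000 nM, lies within the usual scatter of compound 1 at 7540 nM. Compound 2 gives 14300 nM. The gap between compound 3 and compound 2 lies beyond the scatter, with less compound tolerated in the case of compound 3.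

The step to compound 4 `Cc1cc(-c2ccc(C#N)cc2)ccc1C(O)c1ccnc(Nc2ccc(C#N)cc2)n1` is the two compounds have the same atoms and bonds; at least one stereo element is drawn with a configuration in one of them and without one in the other: 1 of 1 stereo elements differ; a stereocentre at a saturated chain carbon is drawn S in compound 3 and without a configuration in compound 4. The two compounds have the same atoms and bonds, and a stereocentre at a saturated chain carbon is drawn S in compound 3 and without a configuration in compound 4.

Within the data shown here, the only measured step, a 1.9-fold higher number from compound 1 to compound 2 (0.28 log units; within the scatter), is fluoro in place of chloro on an aromatic carbon. It is a different kind of change and bears on this one only as a guide to how small a step can be here. Among the measured compounds shown here, no measured pair tests a stereocentre, so the data give no direction for this change. In this assay the expectation therefore rests on compound 3 at 4000 nM, with no shift beyond the scatter. The expected size is a 1.1-fold higher number from compound 3 to compound 4 (0.05 log units; within the scatter). For compound 4 the estimated value is 4500 nM, with an expected range from 2300 nM to 9000 nM.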

Compound 4, half-maximal cytotoxic concentration: 9940 nM
Compound 4: middle estimate off by 2.2-fold (0.34 log units), on the low side, outside the stated range (above it).
By their numbers in this assay, from the lowest: compounds 3, 1, 4 and 2 (each within the scatter of the next, the first and the last beyond it).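

In this assay, among these compounds, a 2.5-fold higher number from compound 3 to compound 4 (0.40 log units; beyond the scatter), the first step that concerns the stereocentre at a saturated chain carbon; the structures offer one difference to set against this step: the fact that one of compounds 3 and 4 is drawn with a defined configuration and the other without, at the place where they differ. With that stereocentre undrawn, the aromatic substituent does not separate the compounds: a 1.4-fold lower number from compound 2 to compound 4 (0.16 log units; within the scatter), and a 1.3-fold higher number from compound 1 to compound 4 (0.12 log units; within the scatter). Methyl in itself therefore does not set compound 3 apart from compound 1 or compound 2 in these data, since compound 4 carries the same methyl; among the four compounds, only compound 3 has a configuration drawn.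

The compounds shown do not say what compound 4 contains at the undrawn centre, and with no compound drawn R, the S and R forms cannot be compared directly, nor can it be said whether the chloro and fluoro compounds would respond to a drawn S centre as the methyl pair does. Also open, as far as these compounds go, is how this read-out would respond to an amine or a methoxy group in place of the hydroxyl on the stereocentre carbon.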